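The source may hold more compounds than are shown below. What is called first, only, known or untested is meant among the compounds shown, and "the series" means these compounds.

Working notes on the series. Going by the values given here, compound 1 `CC(C)(C)CNc1ncnc2c1ncn2C1O[C@H](CO)[C@@H](O)[C@H]1O` is the one compound here with a numerical read-out: in an assay on cell membranes for binding affinity to adenosine receptor A1 (Cavia porcellus), read by radioligand binding (on this read-out higher numbers stand for weaker inhibition and lower numbers for stronger inhibition), compound 1 gives 17 nM. Compound 2 `CCCn1c(=O)c2nc(-c3nn[nH]n3)[nH]c2n(CCC)c1=O` shares its core with compound 3 and compound 4, the three differing only in the group on the core. For compound 2 the read-out in this assay is a limit of the assay and not a number, > 10000 nM, which is the limit of > 10000 nM in this assay, at which 1 of the 3 values shown sits. For compound 3 `CCCn1c(=O)c2nc(-c3cc4ccccc4s3)[nH]c2n(CCC)c1=O` the read-out in this assay is likewise a limit and not a number, > 100000 nM, which is the limit of > 100000 nM in this assay, at which 1 of the 3 values shown sits. Compound 2 thus stands at a limit, with no number to rank it against compound 1 or compound 3.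

Compound 4 `CCCn1c(=O)c2nc(-c3ccco3)[nH]c2n(CCC)c1=O` has not been measured in this assay. It differs from compound 2 in one place: furan-2-yl in place of 2H-tetrazol-5-yl on an aromatic carbon. No measured step between the compounds shown covers this change, so the expected size of the step rests on the structural change alone. The step from compound 2 to compound 4 is expected to move toward stronger inhibition by an at least 66-fold lower number from compound 2 to compound 4 (1.82 log units; beyond the scatter), beyond the scatter. For compound 4 the estimate in this assay is 150 nM, within 10 nM to 3000 nM.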

Compound 4, inhibition constant: 560 nM
For compound 4 the middle estimate is 3.7-fold (0.57 log units) below the measured one; measured number inside the range.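

On the shared core, the aromatic carbon between two ring nitrogen atoms can carry a group that gives a numerical read-out in this assay: furan-2-yl in place of 2H-tetrazol-5-yl gives an at least 17-fold lower number from compound 2 to compound 4 (1.25 log units; beyond the scatter). Compound 2 stands at a limit of the assay, so this step is known only as a bound: the limit of > 10000 nM in this assay, at which 1 of the 4 values shown sits. Compound 3, with a different group at the same place, also stands at a limit, so a numerical read-out at this position is not shared by every group shown: the limit of > 100000 nM in this assay, at which 1 of the 4 values shown sits.

The compounds shown do not separate the changes counted between the two groups, namely the number of hetero atoms, the hydrogen-bond donor and the hydrogen-bond acceptors, so it remains open which of them goes with the step. Also open, on these data alone, is how thiophen-2-yl, which would replace the furan oxygen with sulfur, or a carboxylic acid on this aromatic carbon would read in this assay, and compound 1 differs from compound 4 in more than one place and gives no guide to either.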